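Alkyl variation in the shared core: compound 3 to compound 4

The source may report more compounds than this note shows. Statements on the series, on what has been measured and on what is new or still open speak of the compounds shown alone.

Compound 1 `CC(C)(C)c1cc(=O)c2ccc(O)cc2o1` opens the set. In an assay on isolated protein for inhibition of Polyunsaturated fatty acid lipoxygenase ALOX15B (Homo sapiens) (a lower number here means a stronger inhibitor, a higher number a weaker inhibitor), compound 1 gives > 100000 nM, a limit of the assay rather than a number. Compound 2 `CC(C)Cc1oc2ccccc2c(=O)c1O` carries an isobutyl group. In this assay compound 2 gives > 100000 nM, again only a limit. Compound 3 `CC(C)(C)c1oc2ccccc2c(=O)c1O` carries tert-butyl in place of the isobutyl. In this assay compound 3 gives > 100000 nM, also a limit. The step that the two limits leave unreadable from compound 2 to compound 3 cannot be read in size or direction, because the limit of > 100000 nM in this assay, at which 3 of the 3 values shown sit, holds for every value shown. Compound 3 thus stands at the limit with the other two, and no ranking among the three is possible.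

Compound 4 `CCCCCc1oc2ccccc2c(=O)c1O` differs from compound 3 by pentyl in place of tert-butyl on an aromatic carbon. Within the data shown here, the only measured step touching this position, a step that the two limits leave unreadable from compound 2 to compound 3, gives no size, so nothing on direction in this assay follows from it. Because the limit of > 100000 nM in this assay, at which 3 of the 3 values shown sit, covers all values shown, compound 4 is expected to remain near that limit, the expected step being a step that the limit leaves unreadable from compound 3 to compound 4. Compound 4 is estimated at 150000 nM, between 20000 nM and 1000000 nM.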

Compound 4, half-maximal inhibitory concentration: > 100000 nM
Compound 4 ended at the assay's limit; the forecaster's own chance of this, stated with the estimate: 80%; the middle value does not contradict the limit.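

No new step can be read among compound 2, compound 3 and compound 4, because their results are limits and not numbers: the limit of > 100000 nM in this assay, at which 4 of the 4 values shown sit.

The compounds shown leave open whether any alkyl group on the shared core gives a value in this assay that is not a limit.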